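Removing the Ring Methyl in a Carboxyphenyl Ether Series

A few compounds are considered here, and "the series" means these few. Any claim that something is new, unique, unknown or untested is made for them only; others in the source may bear on it.

Of the compounds shown here, three of a shared core have been measured in an assay on HEK293 cells for positive allosteric modulation of metabotropic glutamate receptor 2 (Rattus norvegicus), read by thallium flux, with a stated time of 2.5 min; on this read-out higher numbers stand for larger maximal responses and lower numbers for smaller maximal responses. Compound 1 `Cc1cc(C(=O)O)ccc1OCCCCOc1ccc(C(=O)CC(C)C)c(O)c1C` gives 83.9%. Compound 2 `Cc1c(OCCCCOc2ccc(C(=O)O)cc2)ccc(C(=O)CC(C)C)c1O` gives 88% in this assay. Compound 3 `Cc1ccc(C(=O)O)cc1OCCCCOc1ccc(C(=O)CC(C)C)c(O)c1C` gives 76.9% in this assay. Compound 4 `Cc1c(OCCCCOc2cccc(C(=O)O)c2)ccc(C(=O)CC(C)C)c1O` has not yet been measured in this assay.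

From compound 1 to compound 2 the change is hydrogen in place of methyl on an aromatic carbon. It made a number 4.1 percentage points higher from compound 1 to compound 2 (within the scatter). The difference between the core of compound 1 and the core of compound 3 is 5-carboxy-2-methylphenyl in place of 4-carboxy-2-methylphenyl on an oxygen on a saturated carbon; that step was a number 7 percentage points lower from compound 1 to compound 3 (within the scatter). Between the other pair, a number 11.1 percentage points lower from compound 2 to compound 3 (beyond the scatter).

From compound 3 to compound 4 the change is hydrogen in place of methyl on an aromatic carbon. Among the measured compounds shown here, this is the same kind of change as the one from compound 1 to compound 2, not the same: in compound 1 the methyl that leaves is meta to a carboxy group, whereas in compound 3 it is para to a carboxy group. For the measured compounds named here, only one measured instance of the change exists, so the expectation rests on it alone. In this assay a step of a number 4.1 percentage points higher from compound 3 to compound 4 (within the scatter) is expected, about the size of the earlier one, because the earlier step was a number 4.1 percentage points higher from compound 1 to compound 2 (within the scatter). Compound 4 is therefore estimated at 81%, with a range from 70% to 92%.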

Compound 4, largest response reached (reported as percent of maximum), in percent of the reference or control that the assay uses: 84.5%
Compound 4: the middle estimate sits 3.5 percentage points below what was measured; the range from low to high includes it.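

Hydrogen in place of methyl on an aromatic carbon has now been read on two cores in this assay, and the two readings do not differ beyond what repeated measurements allow: the same change on two cores in this assay, a number 4.1 percentage points higher (within the scatter) from compound 1 to compound 2 and a number 7.6 percentage points higher (within the scatter) from compound 3 to compound 4, 3.5 percentage points apart, within the scatter of two such steps. The new reading, a number 7.6 percentage points higher from compound 3 to compound 4 (within the scatter), therefore gives no sign that the outcome of this change depends on whether the carboxy group is placed as in 4-carboxy-2-methylphenyl or as in 5-carboxy-2-methylphenyl. It does not show that removing the methyl raises the response, since each step on its own lies within the scatter, as do a number 3.5 percentage points lower from compound 2 to compound 4 (within the scatter) and a number 0.6 percentage points higher from compound 1 to compound 4 (within the scatter), and two cores cannot establish a rule for the wider series.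

Still open, going by these compounds, is whether a replacement other than hydrogen, such as chlorine or a methoxy group in place of the methyl, would leave the maximal response similarly unmoved. Also open, on these data alone, is how the series responds to a longer chain joining the two ether oxygens, or to a tetrazole in place of the carboxylic acid.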